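The source may report more compounds than this note shows. Statements on the series, on what has been measured and on what is new or still open speak of the compounds shown alone.

Measured compounds:
- Compound 1, `COC(=O)CC(=O)N1N=C(c2ccc(N3CCN(C)CC3)cc2)CC1c1ccc(N(C)C)cc1`: -2.2%
- Compound 2, `CN1CCN(c2ccc(C3=NN(S(=O)(=O)c4ccc(F)cc4)C(c4ccc(N(C)C)cc4)C3)cc2)CC1`: 95.7%

Both were tested in a functional assay on NCI-H1975 cells (Homo sapiens) for inhibition, read by sulforhodamine B assay, tested at 10 uM; a lower number here means less inhibition, a higher number more inhibition at the concentration tested (going by the name of the read-out). Going by the values given here, compound 2 gives the higher of the two numbers, and the one step that connects the pair, a number 97.9 percentage points higher from compound 1 to compound 2 (beyond the scatter), is large. That step changes the group on the ring nitrogen, not the substituent on the aromatic ring attached to the sulfonyl group.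

Compound 3, `CN1CCN(c2ccc(C3=NN(S(=O)(=O)c4ccc(OC(F)(F)F)cc4)C(c4ccc(N(C)C)cc4)C3)cc2)CC1`, has not been measured. It differs from compound 2 at one point: trifluoromethoxy in place of fluoro on an aromatic carbon. No measured step touches this position, so nothing shown speaks directly to the size of the change; the only guide is that the number for compound 2 in this assay is already high. Compound 3 is therefore expected to stay high, with a step of a number 5.7 percentage points lower from compound 2 to compound 3 (within the scatter), which is no more than the usual scatter. The estimate for compound 3 is 90%, within a range from 65% to 100%.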

Compound 3, a percentage reported as inhibition, at one concentration (the size of the read-out at that concentration, not a potency): 26.5%
Beside the measured number, compound 3's estimate is 63.5 percentage points above it; the whole stated range lies above it.
By their numbers in this assay, from the lowest: compound 1; then compound 3; then compound 2.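

In this assay, trifluoromethoxy in place of fluoro on the aromatic carbon gives a number 69.2 percentage points lower from compound 2 to compound 3 (beyond the scatter) in a single change. Going by these compounds alone, this position, which no earlier step touched, therefore matters as well as the group on the ring nitrogen: compound 3 keeps the sulfonyl link of compound 2, yet that link alone does not preserve the high number. Nothing available here accounts for the drop.

With only fluoro and trifluoromethoxy shown at this position, it remains open whether the drop follows the five heavy atoms of the new group, its oxygen or its three fluorines. A methoxy group, a trifluoromethyl group or an amine on the same carbon could help separate these possibilities, and each would show how far the number moves from that of compound 2.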